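A few compounds are considered here, and "the series" means these few. Any claim that something is new, unique, unknown or untested is made for them only; others in the source may bear on it.

Measured compounds:
Compound 1, `Cc1ccc2[nH]c(C(=O)N[C@@H]3CN(S(=O)(=O)c4ccccc4)C[C@H]3C(=O)NCCN(C)C)cc2c1`: 79%
Compound 2, `O=C(N[C@H]1CN(S(=O)(=O)c2ccccc2)C[C@@H]1C(=O)N[C@H]1CCCNC1)c1cc(C2CC2)n[nH]1`: 81%

In a functional assay on HEK293 cells for agonist activity at growth hormone secretagogue receptor type 1 (Homo sapiens), read by HTRF and inositol phosphate accumulation, with a stated time of 90 min, in the presence of a further agent that is not named here (a higher number here means a larger maximal response, a lower number a smaller maximal response), compound 2 gives 81%, the higher of the two numbers, while compound 1 gives 79%; the two values lie within the scatter of each other, so no order between them can be read.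

Compound 3, `O=C(N[C@H]1CN(S(=O)(=O)c2ccccc2)C[C@@H]1C(=O)N[C@H]1CCCNC1)c1cc(-c2ccc(Cl)cc2)on1`, differs from compound 2 by the change (5-(4-chlorophenyl)-1,2-oxazol-3-yl in place of 3-cyclopropyl-1H-pyrazol-5-yl on a carbonyl carbon). Without any measured step to rest on, a modest downward shift in this assay is expected, and the expected step of a number 6 percentage points lower from compound 2 to compound 3 (within the scatter) lies within the scatter. Compound 3 is therefore estimated at 75%, with a range from 55% to 95%.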

Compound 3, largest response reached (Emax), in percent of the reference or control that the assay uses: 91%
The estimate for compound 3 lay 16 percentage points below the measured number; the range from low to high includes it.
By their numbers in this assay, from the lowest: compounds 1, 2 and 3 (each within the scatter of the next, the first and the last beyond it).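

In this assay the exchange of 3-cyclopropyl-1H-pyrazol-5-yl for 5-(4-chlorophenyl)-1,2-oxazol-3-yl on a carbonyl carbon gives a number 10 percentage points higher from compound 2 to compound 3 (within the scatter) and so stays within the scatter. This single pair shows that this place can carry the entering group, with its added six-membered aromatic ring and 0 hydrogen-bond donors, without a step beyond the scatter. No measurement here offers an explanation for this step.

The compounds shown leave open whether a plain phenyl, or an amine or carboxylic acid in place of the chlorine, would keep the maximal response. They also leave open how a simple methyl on the 1,2-oxazole would compare.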